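A few compounds are considered here, and "the series" means these few. Any claim that something is new, unique, unknown or untested is made for them only; others in the source may bear on it.

Compound 1 `CCCCC(C)Nc1nc(C)nc2c(-c3ccc(OC)nc3C)c(C)nn12` carries a (1-methylpentyl)amino group on the shared core, and in an assay on cell membranes for displacement of a labelled ligand from corticotropin-releasing factor receptor 1 (Rattus norvegicus) (a higher number here means a weaker inhibitor, a lower number a stronger inhibitor), compound 1 gives 5.1 nM. Of the three numbers in hand it stands lowest. For the measured compounds named here, compound 2 `CCCCN(CCC)c1nc(C)nc2c(-c3c(C)cc(N(C)C)nc3C)c(C)nn12` gives 12.8 nM in this assay, and compound 3 `CCCN(CCC)c1nc(C)nc2c(-c3c(C)cc(N(C)C)nc3C)c(C)nn12` gives 14.9 nM; both carry a dialkylamino group at the same position of the core but also a different aryl ring, so no single-point step from compound 1 to either is available, and only the gap in the values themselves can be noted. Going by the values given here, the one measured step, a 1.2-fold higher number from compound 2 to compound 3 (0.07 log units; within the scatter), shortens one chain of the dialkylamino group and leaves the number essentially unchanged.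

Compound 4 `CCN(CC)c1nc(C)nc2c(-c3ccc(OC)nc3C)c(C)nn12` differs from compound 1 by diethylamino in place of (1-methylpentyl)amino on an aromatic carbon. Among the compounds with values here, the change replaces a secondary amine with a tertiary one and shortens the alkyl portion at once, and no measured pair isolates that exchange on the aryl ring of compound 1. Within the data shown here, the step from compound 2 to compound 3 suggests that trimming a chain on a dialkylamino group costs little; the move from a monoalkyl to a dialkyl amine has no counterpart here. A moderate loss is therefore expected, a 2.9-fold higher number from compound 1 to compound 4 (0.47 log units; beyond the scatter), with a wide range. Compound 4 is estimated at 15 nM in this assay, between 5 nM and 50 nM.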

Compound 4, half-maximal inhibitory concentration: 12 nM
Beside the measured number, compound 4's estimate is 1.3-fold (0.10 log units) above it; the range from low to high includes it.
By their numbers in this assay, from the lowest: compound 1; then compounds 4, 2 and 3 (each within the scatter of the next).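

For the compounds shown here, at this position, on an aromatic carbon between two ring nitrogen atoms, diethylamino in place of (1-methylpentyl)amino gives a 2.4-fold higher number from compound 1 to compound 4 (0.37 log units; beyond the scatter) in this assay, the first measured change of this group with the rest of compound 1 held constant. The loss is modest, so on this core a tertiary amine remains compatible with binding in this assay, although the exchange goes from 1 hydrogen-bond donor to 0 hydrogen-bond donors and from 7 heavy atoms to 5 heavy atoms in a single step, which leaves these changes inseparable. No measurement in hand accounts for the size of this step.

Going by these compounds, whether the loss follows from the second alkyl chain on the nitrogen or from the shorter, unbranched alkyl portion stays open, and a simple ethylamino group or a dipropylamino group on the aryl ring of compound 1 would help separate the two. Also open, on these data alone, are whether the same exchange gives a similar step with the aryl ring of compound 2, and how a cyclic amine such as morpholine or an ether-bearing bis(2-methoxyethyl)amino group behaves at this position.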